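A Morpholine Amide Replaces the Isoxazolyl Amide

A few compounds are considered here, and "the series" means these few. Any claim that something is new, unique, unknown or untested is made for them only; others in the source may bear on it.

The series rests on a shared core in which a benzimidazole-bearing alkylidene thiazolidinedione carries an acetamide side chain, tested in a functional assay on PC-3 cells (Homo sapiens) for inhibition, read by MTT assay, with a stated time of 48 h; on this read-out lower numbers stand for stronger inhibition and higher numbers for weaker inhibition. Compound 1 `Cn1c(/C=C2\SC(=O)N(CC(=O)Nc3cc(C(C)(C)C)on3)C2=O)nc2ccccc21` gives only a limit of this assay, > 50000 nM. Compound 2 `CCn1c(/C=C2\SC(=O)N(CC(=O)Nc3cc(C(C)(C)C)on3)C2=O)nc2ccccc21` likewise gives only a limit, > 50000 nM. Compound 3 `CCn1c(/C=C2\SC(=O)N(CC(=O)Nc3nc(-c4ccccc4)cs3)C2=O)nc2ccccc21` also gives only a limit, > 50000 nM. The two measured steps, a step that the two limits leave unreadable from compound 1 to compound 2 and a step that the two limits leave unreadable from compound 2 to compound 3, thus cannot be read in size or direction, because every value sits at the limit of > 50000 nM in this assay, at which 3 of the 3 values shown sit.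

Compound 4 `CCn1c(/C=C2\SC(=O)N(CC(=O)N3CCOCC3)C2=O)nc2ccccc21` differs from compound 2 in one place: morpholin-4-yl in place of (5-(tert-butyl)-1,2-oxazol-3-yl)amino on a carbonyl carbon. Neither measured step bears on this change, since the step from compound 2 to compound 3 exchanged one amide-borne heteroaryl group for another and left the amide nitrogen in place, whereas here the amide-type nitrogen with its donor is lost and a saturated ring enters. Because all three known values sit at the limit of > 50000 nM in this assay, at which 3 of the 3 values shown sit, the most that can be said of compound 2 is that it lies at the limit, and the account therefore expects compound 4 to remain near that limit, with no step beyond the scatter readable. The expected step from compound 2 to compound 4 is a step that the limit leaves unreadable from compound 2 to compound 4. For compound 4 the estimate is 60000 nM, with a range from 20000 nM to 200000 nM.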

Compound 4, half-maximal inhibitory concentration: > 50000 nM
Compound 4 gave a limit, no number; the forecaster's own chance of this, stated with the estimate: 80%; the middle value is on the limit's open side.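

In this assay compound 4 gives only a limit, > 50000 nM. Compound 2 also stands at a limit, so no step can be read between compound 2 and compound 4: the limit of > 50000 nM in this assay, at which 4 of the 4 values shown sit.

The compounds shown leave open how far any of them lies past that limit, and which change to the shared core would bring a readable value in this assay.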